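A Hydroxynaphthyl Hydrazone Replaces the Bromophenyl Group

This account rests on a few compounds, and the source may have more. Where it says the series, first, only, none or still open, it means among the compounds named here.

Two hydrazones built on one shared core have been measured in a functional assay on MGC-803 cells (Homo sapiens) for antiproliferative activity, read by MTT assay, with a stated time of 72 h; a lower number here means a stronger inhibitor, a higher number a weaker inhibitor. Compound 1 `CCCSc1nc(N/N=C/c2c[nH]c3ccccc23)c2nnn(Cc3ccccc3)c2n1` gives 7410 nM in this assay, while compound 2 `CCCSc1nc(N/N=C/c2ccc(Br)cc2)c2nnn(Cc3ccccc3)c2n1` gives 34900 nM. For the measured compounds named here, compound 2 therefore stands at the highest of the two numbers, and the single step between them, a 4.7-fold higher number from compound 1 to compound 2 (0.67 log units; beyond the scatter), separates them by more than the usual scatter.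

Compound 3 `CCCSc1nc(N/N=C/c2c(O)ccc3ccccc23)c2nnn(Cc3ccccc3)c2n1` has not yet been measured. It differs from compound 2 in one place: 2-hydroxynaphthalen-1-yl in place of 4-bromophenyl on a carbon with a double bond to nitrogen. Going by the values given here, the only measured step that bears on this change is the one already described, in which a two-ring aromatic group on the carbon double-bonded to nitrogen was exchanged for 4-bromophenyl and the number rose modestly. Compound 3 brings a two-ring aromatic group back to that carbon, so a downward step in this assay is expected, estimated as a 2.9-fold lower number from compound 2 to compound 3 (0.46 log units; beyond the scatter). On that basis compound 3 is expected to give about 12000 nM in this assay, within a range from 4000 nM to 40000 nM.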

Compound 3, half-maximal inhibitory concentration: 3710 nM
Beside the measured number, compound 3's estimate is 3.2-fold (0.51 log units) above it; the measured number lies below the stated range.
By their numbers in this assay, from the lowest: compounds 3 and 1 (each within the scatter of the next); then compound 2.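

In this assay, placing 2-hydroxynaphthalen-1-yl in place of 4-bromophenyl on a carbon with a double bond to nitrogen gives a 9.4-fold lower number from compound 2 to compound 3 (0.97 log units; beyond the scatter), so this place now separates 4-bromophenyl from two different groups rather than from 1H-indol-3-yl alone. For the compounds shown here, the two groups with two rings are not told apart here, with a 2.0-fold lower number from compound 1 to compound 3 (0.30 log units; within the scatter) even though the 2-hydroxynaphthalen-1-yl group and the 1H-indol-3-yl group differ in their ring atoms, and across these three compounds both two-ring groups give lower numbers than the one-ring 4-bromophenyl group, with no compound going against that reading. Nothing available explains the size of the step from the bromophenyl group or assigns it to the second ring or to the hydroxyl group.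

The compounds shown do not separate those two features, which a plain naphthalen-1-yl group without the hydroxyl, or a 2-methoxynaphthalen-1-yl group, would address directly. They also leave open how a 4-hydroxyphenyl group, with a single ring and a hydroxyl in place of the bromine, would fall relative to these three compounds.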